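The source may report more compounds than this note shows. Statements on the series, on what has been measured and on what is new or still open speak of the compounds shown alone.

Measured so far:
compound 1, `CC(C)c1ccc(/C=C/C(=O)OCCc2ccccc2)cc1`: 0%
compound 2, `C=CCNC(=O)/C=C/c1ccccc1`: 64%

Compound 2 stands highest of the two numbers in a functional assay on the whole organism for inhibition, with Brassica rapa subsp. chinensis as the target, with a stated time of 3 days, tested at 100 ppm; on this read-out lower numbers stand for less inhibition of growth and higher numbers for more inhibition of growth at the one concentration tested. The nearest is compound 1, whose value of 0% lies far lower, beyond the scatter. Compound 3, `CC(C)OC(=O)/C=C/c1ccccc1`, is not yet measured. Change from compound 2: isopropoxy in place of allylamino on a carbonyl carbon. Going by the values given here, no measured pair differs in one place only, so the step size rests on expectation. Because compound 1 gives 0% in this assay, a fall is expected. The expected step of a number 34 percentage points lower from compound 2 to compound 3 (beyond the scatter) is downward and beyond the scatter. Compound 3 is expected to give 30%, within 5% to 60%.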

Compound 3, percent growth inhibition at one concentration: 2%
Compound 3: middle estimate off by 28 percentage points, on the high side; the whole stated range lies above it.
By their numbers in this assay, from the lowest: compounds 1 and 3 (each within the scatter of the next); then compound 2.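

In this assay, going by these compounds alone, isopropoxy in place of allylamino on a carbonyl carbon gives a number 62 percentage points lower from compound 2 to compound 3 (beyond the scatter), the first step that can be read at a single place. The heavy-atom count stays the same, so that count alone does not hold the inhibition, while the hydrogen-bond donor and the double bond of allylamino leave together. Nothing measured here bears on the cause of the fall.

Open, going by these compounds, is which of these two losses matters: isopropylamino would keep the nitrogen without the double bond, and allyloxy would keep the double bond without the nitrogen.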